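From a butyl chain to a benzyl group

The compounds below may be only part of what the source reports. "The series", "measured", "known", "first", "only" and "open" are said of these compounds alone.

In a functional assay on HCC827 cells (Homo sapiens) for inhibition, read by fluorescence, with a stated time of 72 h (a higher number here means a weaker inhibitor of growth, a lower number a stronger inhibitor of growth), compound 1 `COc1ccc(Cn2cnc3c(Nc4cccc(Cl)c4)nc(N[C@H]4CC[C@H](N)CC4)nc32)cc1` gives 18700 nM, while compound 2 `CCCCn1cnc2c(Nc3cccc(Cl)c3)nc(N[C@H]3CC[C@H](N)CC3)nc21` gives 7200 nM. Compound 2 therefore holds the lower of the two numbers and is the stronger growth inhibitor of this pair.

The next compound is compound 3 `N[C@H]1CC[C@H](Nc2nc(Nc3cccc(Cl)c3)c3ncn(Cc4ccccc4)c3n2)CC1`, which shares the core of compound 2 and differs from it as follows: phenyl in place of propyl on a saturated chain carbon bound to an aromatic nitrogen. The rest of the two structures is the same. Cut one bond further out, the same difference reads butyl to benzyl. Like compound 1, compound 3 thus carries an aromatic ring at this place.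

Going by the values given here, only one measured step bears on this change, and it is modest: a 2.6-fold lower number from compound 1 to compound 2 (0.41 log units; beyond the scatter). With so little evidence, a small rise in the number is the most that can be expected, and it may not exceed the scatter. The expected step is a 1.7-fold higher number from compound 2 to compound 3 (0.22 log units; within the scatter). For compound 3 the estimated value is 12000 nM, with an expected range from 5500 nM to 26000 nM.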

Compound 3, concentration for 50% growth inhibition: 13700 nM
For compound 3 the middle estimate is 1.1-fold (0.06 log units) below the measured one, and the stated range covers the measured number.
By their numbers in this assay, from the lowest: compounds 2, 3 and 1 (each within the scatter of the next, the first and the last beyond it).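

Replacing the butyl chain with a benzyl group gives a 1.9-fold higher number from compound 2 to compound 3 (0.28 log units; within the scatter), so adding an aromatic ring at this place, on its own, does not separate the two compounds beyond the usual variation between repeat measurements. Going by these compounds alone, the pair of compound 1 and compound 3 isolates the methoxy group for the first time, and removing it gives a 1.4-fold lower number from compound 1 to compound 3 (0.14 log units; within the scatter); the earlier gap of a 2.6-fold lower number from compound 1 to compound 2 (0.41 log units; beyond the scatter) thus divides into two smaller steps, neither of which is beyond the scatter by itself, although together they are. No independent measurement is available to explain these small differences.

As far as these compounds go, it remains open whether a longer chain, a chain ending in an amine or a carboxylic acid, or a benzyl ring carrying a fluorine atom instead of the methoxy group would shift the number beyond the scatter. These three compounds also cannot show whether any group at this place could produce a much stronger inhibitor of growth, since the butyl, benzyl and methoxybenzyl groups span only a narrow range.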